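Chain length at the anomeric amine in a glucose-derived series

This account rests on a few compounds, and the source may have more. Where it says the series, first, only, none or still open, it means among the compounds named here.

Measured so far:
compound 1 `NC[C@H]1OC(CO)C(O)C(O)C1O` — 34500000 nM
compound 2 `NCC[C@@H]1OC(CO)C(O)C(O)C1O` — 4500000 nM

Both compounds were examined in an assay on isolated protein (Oryctolagus cuniculus) for binding affinity to glycogen phosphorylase, brain form (Homo sapiens); on this read-out higher numbers stand for weaker inhibition and lower numbers for stronger inhibition. Compound 2 holds the lowest of the two numbers; in this assay compound 1 gives 34500000 nM, a gap that lies beyond the scatter. For the measured compounds named here, no step between measured compounds that differ in one place is available, so the pair says only that the 2-aminoethyl compound sits lower than the aminomethyl compound of the other configuration.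

Compound 3 `NC[C@@H]1OC(CO)C(O)C(O)C1O` follows from compound 2 by amino in place of aminomethyl on a saturated chain carbon bound to a saturated ring carbon. Going by the values given here, compound 2 is the only directly connected anchor, and no measured single-point step backs this change. The shorter chain is expected to move the number upward, as a step beyond the scatter, toward the region where compound 1 with its 34500000 nM stands. The expected step of a 3.3-fold higher number from compound 2 to compound 3 (0.52 log units; beyond the scatter) is therefore a loss. For compound 3 the estimate in this assay is 15000000 nM, with a range from 4000000 nM to 60000000 nM. Given how weak the whole series is, a limit rather than a number remains a real possibility.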

Compound 3, inhibition constant: 16800000 nM
Beside the measured number, compound 3's estimate is 1.1-fold (0.05 log units) below it; the measured number falls inside the stated range.
By their numbers in this assay, from the lowest: compound 2; then compound 3; then compound 1.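

In this assay the earlier pair mixed a change of chain length with a change of configuration, and the new compound separates the two. Going from 2-aminoethyl to aminomethyl on a saturated chain carbon bound to a saturated ring carbon gives a 3.7-fold higher number from compound 2 to compound 3 (0.57 log units; beyond the scatter), while the change at a stereocentre on a saturated ring carbon gives a 2.1-fold lower number from compound 1 to compound 3 (0.31 log units; beyond the scatter), so both chain length and configuration at this place move the number, each by a modest step beyond the scatter. The configuration step needs care in reading, and one point limits it: the fact that one of compounds 1 and 3 is drawn with a defined configuration and the other without, at the place where they differ

As far as these compounds go, whether a longer chain such as 3-aminopropyl would lower the number further, or whether a hydroxyl or a carboxylic acid in place of the amine would keep any of the gain, stays open. From the compounds shown here alone, how the 2-aminoethyl chain behaves in the configuration of compound 1 also stays open, so it is unknown whether the chain and configuration steps are independent of each other.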